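Replacing a branched amine on the thiocarbonyl carbon with pyrrolidine

The source may hold more compounds than are shown below. What is called first, only, known or untested is meant among the compounds shown, and "the series" means these compounds.

Compound 2 `CCN(Cc1ccncc1)C(=S)SCc1ccc(C(=O)Nc2ccccc2N)cc1` carries an ethyl((pyridin-4-yl)methyl)amino group on the thiocarbonyl carbon. In a functional assay on A-375 cells (Homo sapiens) for antiproliferative activity, read by CCK-8 assay, with a stated time of 72 h, tested at 2 uM (a lower number here means a weaker effect, a higher number a stronger effect of the compound at the concentration tested), compound 2 gives 67.2%, the highest of the three numbers measured here. Compound 1 `Nc1ccccc1NC(=O)c1ccc(CSC(=S)N2CCN(C3CCCCC3)CC2)cc1` gives 31.7% and compound 3 `COc1ccc(N2CCN(C(=S)SCc3ccc(C(=O)Nc4ccccc4N)cc3)CC2)cc1` gives 28.1%; both values lie beyond the scatter below that of compound 2. Among the compounds with values here, the only step between two measured compounds, a number 3.6 percentage points lower from compound 1 to compound 3 (within the scatter), exchanges one substituent on the ring amine nitrogen for another and leaves the read-out unchanged within the scatter.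

Compound 4 `Nc1ccccc1NC(=O)c1ccc(CSC(=S)N2CCCC2)cc1` is the unmeasured member. It differs from compound 2 as follows: pyrrolidin-1-yl in place of ethyl((pyridin-4-yl)methyl)amino on a thiocarbonyl carbon. Within the data shown here, no measured step touches this exact change; the step from compound 1 to compound 3 concerns a different position and only shows that the two ring-amine compounds sit close together. Compounds 1 and 3, which carry a ring amine at the same place as compound 4, both sit well below compound 2, so a drop is expected for compound 4 rather than a gain, though its size is uncertain. The estimated step is a number 27.2 percentage points lower from compound 2 to compound 4 (beyond the scatter). Compound 4 is therefore expected to give about 40%, with a plausible range from 22% to 62%.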

Compound 4, a percentage reported as inhibition, at one concentration (the size of the read-out at that concentration, not a potency): 30.2%
For compound 4 the middle estimate is 9.8 percentage points above the measured one; the measured number falls inside the stated range.
By their numbers in this assay, from the lowest: compounds 3, 4 and 1 (each within the scatter of the next); then compound 2.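

In this assay, the exchange of ethyl((pyridin-4-yl)methyl)amino for pyrrolidin-1-yl on the thiocarbonyl carbon gives a number 37 percentage points lower from compound 2 to compound 4 (beyond the scatter) and is the only listed step at this place, so it ties the change in read-out directly to this substituent. Compound 4 lies within the scatter of compound 1 and compound 3, which shows that, among these four compounds, the small unsubstituted ring amine on this carbon does no better than the two larger substituted ones; only the open-chain amine of compound 2 stands apart. Nothing in the data available here explains the size of this step.

As far as these compounds go, it remains open which part of the group that leaves carries the higher number: the ethyl chain, the pyridin-4-yl ring or the open-chain amine itself, and a diethylamino or an ethyl(benzyl)amino group on the thiocarbonyl carbon would begin to separate these. From the compounds shown here alone, it also remains open whether a step of this size at a single concentration would carry over to a potency.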